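The compounds below may be only part of what the source reports. "The series", "measured", "known", "first", "only" and "open" are said of these compounds alone.

All numbers below come from a functional assay on MDA-MB-231 cells (Homo sapiens) for inhibition, read by MTT assay, with stated times of 18 h and 4 h; on this read-out lower numbers stand for stronger inhibition and higher numbers for weaker inhibition.

compound 1, `CCCCCCOP(=O)(O)OCCSC(=S)N1CCCC1`: 54000 nM
compound 2, `CCCCCCOP(=O)(O)OCCSC(=S)N1CCCCC1`: 85000 nM
compound 3, `CCCCCCCCCCCCCCCCOP(=O)(O)OCCSC(=S)N1CCCCC1`: 100000 nM

Compound 4, `CCCCCCCCCCCCCCCCOP(=O)(O)OCCSC(=S)N1CCCC1`, is the one still to be measured in this assay. The three measured numbers sit close together. Between compound 2 and compound 1 the change is pyrrolidin-1-yl in place of piperidin-1-yl on a thiocarbonyl carbon, and it gave a 1.6-fold lower number from compound 2 to compound 1 (0.20 log units; within the scatter). Between compound 2 and compound 3 the change is decyl in place of hydrogen on a saturated chain carbon, six bonds along the chain from an oxygen on an unsaturated carbon, and it gave a 1.2-fold higher number from compound 2 to compound 3 (0.07 log units; within the scatter). No step is counted between compound 1 and compound 3; their two values simply stand as given above.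

The change from compound 3 to compound 4 is pyrrolidin-1-yl in place of piperidin-1-yl on a thiocarbonyl carbon. Among the compounds with values here, this is the same change as the one from compound 2 to compound 1: the group that leaves, the group that enters and the place where it happens are the same word for word. The two cores differ as decyl in place of hydrogen on a saturated chain carbon, six bonds along the chain from an oxygen on an unsaturated carbon, which by itself moved the number only within the scatter.

With a single earlier instance of this change, and that instance within the scatter, the expectation is that compound 4 stays close to compound 3, with a step of a 1.4-fold lower number from compound 3 to compound 4 (0.15 log units; within the scatter) expected because the earlier instance gave a 1.6-fold lower number from compound 2 to compound 1 (0.20 log units; within the scatter). On that basis compound 4 is estimated at 70000 nM in this assay. Within the data shown here, the expected range for compound 4 runs from 35000 nM to 140000 nM, wide because the one earlier instance gave a 1.6-fold lower number from compound 2 to compound 1 (0.20 log units; within the scatter) and that step lay within the scatter.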

Compound 4, half-maximal inhibitory concentration: 69000 nM
Beside the measured number, compound 4's estimate is 1.0-fold (0.01 log units) above it, and the stated range covers the measured number.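

In this assay, pyrrolidin-1-yl in place of piperidin-1-yl on a thiocarbonyl carbon gives a 1.4-fold lower number from compound 3 to compound 4 (0.16 log units; within the scatter), and the two instances of this change agree: the same change on two cores in this assay, a 1.6-fold lower number (0.20 log units; within the scatter) from compound 2 to compound 1 and a 1.4-fold lower number (0.16 log units; within the scatter) from compound 3 to compound 4, 1.1-fold (0.04 log units) apart, within the scatter of two such steps

The decyl change read on the pyrrolidin-1-yl compounds gives a 1.3-fold higher number from compound 1 to compound 4 (0.11 log units; within the scatter), and it agrees with its instance on the piperidin-1-yl compounds: the same change on two cores in this assay, a 1.2-fold higher number (0.07 log units; within the scatter) from compound 2 to compound 3 and a 1.3-fold higher number (0.11 log units; within the scatter) from compound 1 to compound 4, 1.1-fold (0.04 log units) apart, within the scatter of two such steps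

This shows that neither change moved the number beyond the scatter on either core, but every step here lies within the scatter, so the agreement does not show that either change has a real effect of its own, nor that a fixed increment would carry to a third core.

Still open, on these data alone, is whether any group on the thiocarbonyl carbon can move the number beyond the scatter, for example a morpholin-4-yl or a dimethylamino group in place of the two rings seen here. Also open, as far as these compounds go, is how a longer chain such as octadecyl, or a chain carrying a terminal carboxylic acid, would read in this assay on the shared core.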